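Three Measured Compounds and One Awaiting Its Number

The compounds below may be only part of what the source reports. "The series", "measured", "known", "first", "only" and "open" are said of these compounds alone.

Measured in an assay on cells with melanin-concentrating hormone receptor 1 (Homo sapiens) as the target, read by radioligand binding; on this read-out higher numbers stand for weaker inhibition and lower numbers for stronger inhibition:
compound 1, `CC(CNCc1ccsc1)Oc1cccc2ccc(N)nc12`, 10 nM
compound 2, `Nc1ccc2cccc(OCCNCc3ccoc3)c2n1`, 660 nM
compound 3, `CC(C)c1ccc(C(=O)NCCCOc2cccc3ccc(N)nc23)cc1`, 60 nM

Compound 3 stands second highest of the three numbers. Its nearest neighbour is compound 1, whose number is lower by a margin beyond the scatter; furthest is compound 2, whose number is higher, again beyond the scatter. Compound 4, `COc1cccc(C(=O)NCCCOc2cccc3ccc(N)nc23)c1`, keeps the shared core of compound 3 and differs only in 3-methoxyphenyl in place of 4-isopropylphenyl on a carbonyl carbon. Among the measured compounds shown here, no measured pair shows this change, so the account rests on compound 3 alone. A small step is expected in this assay, toward a somewhat higher number, and the step of a 1.7-fold higher number from compound 3 to compound 4 (0.22 log units; within the scatter) is estimated to stay close to the scatter. Compound 4 is therefore expected at about 100 nM, within 30 nM to 400 nM.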

Compound 4, half-maximal inhibitory concentration: 2 nM
Compound 4: middle estimate off by 50-fold (1.70 log units), on the high side, outside the stated range (below it).
By their numbers in this assay, from the lowest: compound 4; then compound 1; then compound 3; then compound 2.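

In this assay the group on the carbonyl carbon proves far from indifferent: with the rest of compound 3 unchanged, 3-methoxyphenyl in place of 4-isopropylphenyl gives a 30-fold lower number from compound 3 to compound 4 (1.48 log units; beyond the scatter) as a large step beyond the scatter. The earlier compounds shown here formed no pair differing in one place and could not show this. Nothing at hand explains the step.

The compounds shown leave open whether the methoxy group, its ring position or the loss of isopropyl matters most. A 4-methoxyphenyl or an unsubstituted phenyl on the same carbonyl carbon would bear on that question.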